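Methylsulfonyl on the amide aryl ring: working notes

The compounds below may be only part of what the source reports. "The series", "measured", "known", "first", "only" and "open" are said of these compounds alone.

Compound 1 `O=C(Nc1ccc(Cl)c(-c2nnc3c(Cl)cccn23)c1)c1ccc(Cl)cc1` and compound 2 `O=C(Nc1ccc(Cl)c(-c2nnc3c(Cl)cccn23)c1)c1ccccc1` share one core and differ only on the aromatic ring attached to the amide carbonyl. In a functional assay on U-251 cells (Homo sapiens) for antiproliferative activity, read by MTT assay, with a stated time of 72 h (on this read-out higher numbers stand for weaker inhibition and lower numbers for stronger inhibition), compound 1 returns only a limit, > 100000 nM, not a number. In this assay, for the measured compounds named here, compound 2 gives 73500 nM, which is the only true number in the set. The other entry, that of compound 1, is the limit just noted. Going by the values given here, the single measured step, an at least 1.3-fold lower number from compound 1 to compound 2 (0.13 log units; that floor lies within the scatter), is hydrogen in place of chloro on an aromatic carbon, and its floor rests on (the limit of > 100000 nM in this assay, at which 1 of the 2 values shown sits).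

Compound 3 `CS(=O)(=O)c1cccc(C(=O)Nc2ccc(Cl)c(-c3nnc4c(Cl)cccn34)c2)c1` is to be measured in this assay. It differs from compound 2 by methylsulfonyl in place of hydrogen on an aromatic carbon. No measured step covers this change; the one step shown on that ring is itself within the scatter. The expectation is therefore a step of a 1.1-fold lower number from compound 2 to compound 3 (0.02 log units; within the scatter), none beyond the scatter. For compound 3 the estimated value in this assay is 70000 nM, with a range from 20000 nM to 200000 nM, and the reading may again come back as a limit.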

Compound 3, half-maximal inhibitory concentration: > 100000 nM
Compound 3 gave a limit, no number (the forecaster's own chance of this, stated with the estimate: 35%); at least 1.4-fold (0.15 log units) between middle value and limit.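

Methylsulfonyl, placed meta to a large group on the ring attached to the amide carbonyl, gives no sign of lowering the number in this assay: the reading is an at least 1.3-fold higher number from compound 2 to compound 3 (0.13 log units; that floor lies within the scatter). Compound 1, with its 4-chlorophenyl, and compound 3, with its 3-(methylsulfonyl)phenyl, both end as limits, so the step between them cannot be read, and among the compounds shown only the unsubstituted phenyl of compound 2 gives a true number. The step from compound 2 is therefore a floor and not a size, and that floor rests on a limit: the limit of > 100000 nM in this assay, at which 2 of the 3 values shown sit.

As far as these compounds go, how far the true value of compound 3 lies past its limit stays open, so the real effect of the change may be small or large. Also open, from the compounds shown here alone, is whether an amine or a carboxylic acid at this same place would return a true number, and whether any group on this ring can give a lower number than compound 2, at 73500 nM.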